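The source may report more compounds than this note shows. Statements on the series, on what has been measured and on what is new or still open speak of the compounds shown alone.

Of the compounds shown here, three have been measured in an assay on isolated protein for inhibition of Amine oxidase [flavin-containing] B (Homo sapiens), read by fluorescence; on this read-out lower numbers stand for stronger inhibition and higher numbers for weaker inhibition. Compound 1 `CCC(C)NC(=O)c1cc2cc(Br)cc(Br)c2oc1=O` gives 45400 nM; compound 2 `CCCCCCN(CCCCCC)C(=O)c1cc2cc(Br)cc(Br)c2oc1=O` gives 7410 nM; compound 3 `O=C(Sc1ccc(Br)cc1)c1cc2ccccc2oc1=O` gives 6500 nM. Compound 3 thus holds the lowest of the three numbers, though its gap to compound 2 is within the scatter, while its gap to compound 1 lies beyond it. Compound 4 `CCCCSC(=O)c1cc2ccccc2oc1=O` is not yet measured in this assay. It differs from compound 3 as follows: butyl in place of 4-bromophenyl on a sulfur. Going by the values given here, no measured pair shows this kind of change, so the size of the step is uncertain. The expected step is estimated as a 2.3-fold higher number from compound 3 to compound 4 (0.36 log units; beyond the scatter), a modest weakening. For compound 4 the estimate in this assay is 15000 nM, with a range from 4000 nM to 60000 nM.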

Compound 4, half-maximal inhibitory concentration: 16000 nM
Beside the measured number, compound 4's estimate is 1.1-fold (0.03 log units) below it, and the stated range covers the measured number.
By their numbers in this assay, from the lowest: compounds 3 and 2 (each within the scatter of the next); then compound 4; then compound 1.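

In this assay, the sulfur position now has its first single-change reading: butyl in place of 4-bromophenyl gives a 2.5-fold higher number from compound 3 to compound 4 (0.39 log units; beyond the scatter), so the group on this sulfur affects the read-out, though the loss is modest. The change removes the aromatic ring and the bromine together, so the step cannot be divided between them. No measured evidence here accounts for the step.

Still open, from the compounds shown here alone, is whether unsubstituted phenyl or 4-chlorophenyl on the sulfur would track compound 3. Going by these compounds, whether a longer chain, such as hexyl, would track compound 4 is also open.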